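Moving the methyl branch along the side chain of compound 1

A few compounds are considered here, and "the series" means these few. Any claim that something is new, unique, unknown or untested is made for them only; others in the source may bear on it.

The series shares one acid-bearing core; the compounds differ in the side chain carrying the secondary alcohol. In an assay on isolated protein for agonist activity at prostaglandin E2 receptor EP2 subtype (Homo sapiens) (on this read-out lower numbers stand for an effect already at smaller amounts and higher numbers for an effect only at larger amounts of compound), compound 1 `CCCCC(C)(C)[C@H](O)/C=C/[C@H]1CCC(=O)N1CCSc1nc(C(=O)O)cs1` gives 0.91 nM, the lowest number of the three measured. Compound 2 `CCOCCC1([C@H](O)/C=C/[C@H]2COC(=O)N2CCSc2nc(C(=O)O)cs2)CCC1` gives 29 nM and compound 3 `CC(C)(C)CCC1([C@H](O)/C=C/[C@H]2COC(=O)N2CCSc2nc(C(=O)O)cs2)CCC1` gives 3700 nM, so compound 1 stands clearly ahead of both.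

Going by the values given here, the only step measured within one site is a 130-fold higher number from compound 2 to compound 3 (2.11 log units; beyond the scatter). That step sits on a different chain and on a different core, so it does not bear directly on compound 4, but it shows that the alkyl part of the side chain can move this assay strongly.

Compound 4 `CCCC[C@H](C)C[C@H](O)/C=C/[C@H]1CCC(=O)N1CCSc1nc(C(=O)O)cs1` differs from compound 1 by 2-methylhexyl in place of 1,1-dimethylpentyl on a saturated chain carbon bound to a double-bonded chain carbon and an oxygen on a saturated carbon. Among the compounds with values here, no measured pair tests this rearrangement, and nothing in the data fixes its direction. The absence of the two methyl groups next to the carbinol carbon in every other compound measured here leaves the estimate open, and a moderate loss is expected rather than a gain, since compound 1 already carries the best number. The expected step is a 5.5-fold higher number from compound 1 to compound 4 (0.74 log units; beyond the scatter), giving an estimated value for compound 4 of 5 nM, within a range of 1.5 nM to 20 nM.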

Compound 4, half-maximal effective concentration: 0.39 nM
For compound 4 the middle estimate is 13-fold (1.11 log units) above the measured one, outside the stated range (below it).
By their numbers in this assay, from the lowest: compound 4; then compound 1; then compound 2; then compound 3.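

In this assay, going by these compounds alone, the first comparison on the core of compound 1 is a rearrangement of the same atoms: 2-methylhexyl in place of 1,1-dimethylpentyl gives a 2.3-fold lower number from compound 1 to compound 4 (0.37 log units; beyond the scatter), a modest step but one beyond the usual scatter. Within the data shown here, the low numbers on this core therefore do not depend on the two methyl groups of 1,1-dimethylpentyl, and the 1-hydroxy-3-methylheptyl arrangement gives the lowest number so far, with one defined stereocentre on the chain that compound 1 does not have. Nothing among the data bears on the reason for this step.

Still open, from the compounds shown here alone, is how the opposite configuration at the methyl-bearing carbon of compound 4 reads, and whether the methyl branch tolerates a larger group such as ethyl, as in 2-ethylhexyl, or a longer chain such as 2-methylheptyl. Going by these compounds, it is equally open whether 2-methylhexyl keeps its advantage on the core of compound 2 and compound 3, where the side chains differ and the numbers are much higher.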